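This account rests on a few compounds, and the source may have more. Where it says the series, first, only, none or still open, it means among the compounds named here.

Compound 1 `CCCCCCCCCCCO[C@@H]1[C@@H](N)[C@@H](O[C@H]2[C@H](O)[C@@H](OCCCCCCC)[C@H](N)C[C@@H]2N)O[C@H](CN)[C@H]1O` was examined in an ADME assay on J774 cells (Mus musculus) for cytotoxicity, read by MTT assay, with a stated time of 24 h, tested at 30 uM (a higher number here means a weaker effect of the compound at the concentration tested, a lower number a stronger effect), where compound 1 gives 39.1%. Among the three compounds measured so far it stands lowest. Compound 2 `CCCCCCCO[C@@H]1[C@@H](N)[C@@H](O[C@H]2[C@H](O)[C@@H](OCCCCCCC)[C@H](N)C[C@@H]2N)O[C@H](CN)[C@H]1O` gives 79.9% in this assay, and compound 3 `CCCCCCCCO[C@@H]1[C@@H](N)[C@@H](O[C@H]2[C@H](O)[C@@H](OCCCCCCCC)[C@H](N)C[C@@H]2N)O[C@H](CN)[C@H]1O` gives 65.1%; the gap from compound 1 to compound 3 and the gap from compound 1 to compound 2 are both beyond the scatter.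

Compound 4 `CCCCCCCCCCCO[C@@H]1[C@@H](N)[C@@H](O[C@H]2[C@H](O)[C@@H](OCCCCCCCCCCC)[C@H](N)C[C@@H]2N)O[C@H](CN)[C@H]1O` has not yet been measured in this assay. It differs from compound 1 by one change: butyl in place of hydrogen on a saturated chain carbon, seven bonds along the chain from an oxygen on a saturated carbon.

Within the data shown here, one measured step bears directly on this change, and it runs the opposite way. From compound 1 to compound 2 a hydrogen replaces a butyl, and this assay moves a number 40.8 percentage points higher from compound 1 to compound 2 (beyond the scatter). The change from compound 1 to compound 4 puts a butyl in place of a hydrogen, so a step of comparable size in the opposite direction is expected, that is, a lower number. Compound 3, whose values sit between those of compound 2 and compound 1, points the same way without adding a second step of this exact kind.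

Compound 4 is therefore expected to give 18% in this assay, a step of a number 21.1 percentage points lower from compound 1 to compound 4 (beyond the scatter), with a range from 4% to 38%.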

Compound 4, a percentage reported as activity, at one concentration (the size of the read-out at that concentration, not a potency): 14.1%
Compound 4: middle estimate off by 3.9 percentage points, on the high side; low and high end bracket the measured number.
By their numbers in this assay, from the lowest: compound 4; then compound 1; then compound 3; then compound 2.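

Butyl in place of hydrogen at this position, on a saturated chain carbon seven bonds along the chain from an oxygen on a saturated carbon, lowers the number in this assay when it is made on the chain that had stayed the same among the earlier steps, a step of a number 25 percentage points lower from compound 1 to compound 4 (beyond the scatter). Among these compounds, until now the only measured step of this kind ran the other way, on the other chain, with a number 40.8 percentage points higher from compound 1 to compound 2 (beyond the scatter), so the result shows that butyl in place of hydrogen goes with a lower number at this position on both chains of the shared core, and that compound 1 does not mark a floor for the series. No measurement shown accounts for this drop, so the pattern stands as an observation on these compounds alone.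

The compounds shown leave open whether a longer chain at this position would lower the number further or whether it would level off. They also leave open how an amine or a carboxylic acid at the end of the chain, in place of its last carbon, would read in this assay.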